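The source may report more compounds than this note shows. Statements on the series, on what has been measured and on what is new or still open speak of the compounds shown alone.

Compound 1 `COC(OC)C1=C(C(=O)OC/C=C/c2ccccc2)C(c2cccc(C(F)(F)F)c2)C(C(=O)O)=CN1` gives 1100 nM in an assay on IMR-32 cells for inhibition of Voltage-dependent N-type calcium channel subunit alpha-1B (Homo sapiens), with a stated time of 5 min; on this read-out higher numbers stand for weaker inhibition and lower numbers for stronger inhibition.
Compound 2 `O=C(O)C1=CNC=C(C(=O)OC/C=C/c2ccccc2)C1c1ccc(Cl)c(Cl)c1` gives 750 nM in this assay.

Compound 2 holds the lowest of the two numbers, though its gap to compound 1 lies within the scatter. Compound 3 `O=C(O)C1=CNC=C(C(=O)OC/C=C/c2ccccc2)C1c1cccc(C(F)(F)F)c1` differs from compound 2 by 3-(trifluoromethyl)phenyl in place of 3,4-dichlorophenyl on a saturated ring carbon. Among the compounds with values here, compound 1 carries the same 3-(trifluoromethyl)phenyl group together with a further group on the core, and its number sits within the scatter of compound 2; no step between measured compounds covers this exchange alone. Compound 3 is therefore expected to give 900 nM (range 400 nM to 2200 nM). The expected change, a 1.2-fold higher number from compound 2 to compound 3 (0.08 log units; within the scatter), amounts to nothing beyond the scatter.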

Compound 3, half-maximal inhibitory concentration: 1200 nM
The estimate for compound 3 lay 1.3-fold (0.12 log units) below the measured number; low and high end bracket the measured number.
By their numbers in this assay, from the lowest: compounds 2, 1 and 3 (each within the scatter of the next).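

On a saturated ring carbon, 3-(trifluoromethyl)phenyl in place of 3,4-dichlorophenyl gives a 1.6-fold higher number from compound 2 to compound 3 (0.20 log units; within the scatter) in this assay, so this exchange of aryl groups shows no change beyond the scatter. Hydrogen in place of dimethoxymethyl on a double-bonded ring carbon gives a 1.1-fold higher number from compound 1 to compound 3 (0.04 log units; within the scatter), so dimethoxymethyl at that position also shows no change beyond the scatter. No measurement at hand bears on either step.

Still open, as far as these compounds go, is whether an aminomethyl group or a longer chain on that double-bonded ring carbon would move the number beyond the scatter. The same holds for a primary amide in place of the carboxy group.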